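From 4-methylphenyl to 3-iodophenyl on the amide nitrogen

A few compounds are considered here, and "the series" means these few. Any claim that something is new, unique, unknown or untested is made for them only; others in the source may bear on it.

Compound 1 (`O=C(CCc1cccc2c1B(O)OC2)Nc1ccc(F)cc1`) and compound 2 (`Cc1ccc(NC(=O)CCc2cccc3c2B(O)OC3)cc1`) share one core and differ at a single aromatic carbon, where methyl stands in place of fluoro. In a functional assay on SK-OV-3 cells (Homo sapiens) for antiproliferative activity, read by MTT assay, with a stated time of 72 h (a higher number here means a weaker inhibitor, a lower number a stronger inhibitor), compound 1 gives 720 nM and compound 2 gives 860 nM as its reading. Among the compounds with values here, the step between them is a 1.2-fold higher number from compound 1 to compound 2 (0.08 log units; within the scatter) and it places compound 2 level with compound 1, the only other compound measured.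

Compound 3 (`O=C(CCc1cccc2c1B(O)OC2)Nc1cccc(I)c1`) keeps the shared core but carries 3-iodophenyl in place of 4-methylphenyl on an amide-type nitrogen, a change counted as 3-iodophenyl in place of 4-methylphenyl on an amide-type nitrogen in full. Within the data shown here, neither measured compound carries iodine or a 3-iodophenyl group, and no measured step covers this exchange directly. Among the measured compounds shown here, the nearest guide is the single swap from compound 1 to compound 2, a weak one that stayed within the scatter. What is expected is a 1.1-fold lower number from compound 2 to compound 3 (0.06 log units; within the scatter) and thus no change beyond the scatter, though with wide uncertainty. For compound 3 the estimated value is 750 nM with an expected range from 280 nM to 2000 nM in this assay.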

Compound 3, half-maximal inhibitory concentration: 630 nM
Beside the measured number, compound 3's estimate is 1.2-fold (0.08 log units) above it, and the stated range covers the measured number.
By their numbers in this assay, from the lowest: compounds 3, 1 and 2 (each within the scatter of the next).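

In this assay, within the data shown here, the exchange of 4-methylphenyl for 3-iodophenyl on the amide-type nitrogen gives a 1.4-fold lower number from compound 2 to compound 3 (0.14 log units; within the scatter) and the exchange of 4-fluorophenyl for the same group gives a 1.1-fold lower number from compound 1 to compound 3 (0.06 log units; within the scatter), so neither step separates compound 3 from the earlier compounds. Among these compounds, until now the only comparison at this place was a swap of fluoro for methyl at a single aromatic carbon, whereas these steps bring in iodine and a group named at ring position 3 rather than 4, and all three readings still lie within the scatter of one another. Nothing shown here offers an explanation for these readings.

Because iodine and its ring position change together in these steps, the compounds shown cannot say what either change does alone, and 4-iodophenyl or 3-methylphenyl on the same nitrogen would be needed to pull them apart. They also leave open how the reading would respond to an amine or a carboxylic acid on this ring, or to a longer chain joining the amide carbonyl to the shared core.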